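Swapping the ring on the piperazine nitrogen, step by step

The source may hold more compounds than are shown below. What is called first, only, known or untested is meant among the compounds shown, and "the series" means these compounds.

Measured compounds:
Compound 1, `COc1cc2nc(N3CCN(c4cccnn4)CC3)nc(N)c2cc1OC` — 0.4 nM
Compound 2, `CCCOc1cc(N2CCN(c3nc(N)c4cc(OC)c(OC)cc4n3)CC2)ncn1` — 0.36 nM

Of the compounds shown here, two have been measured in an assay on brain for binding affinity to Adrenergic receptor alpha-1 (Rattus norvegicus); a lower number here means a stronger inhibitor, a higher number a weaker inhibitor. Compound 1 gives 0.4 nM, and compound 2 gives 0.36 nM. Compound 2 has the smaller of the two numbers, but the step of a 1.1-fold lower number from compound 1 to compound 2 (0.05 log units; within the scatter) is within the scatter, so the two cannot be told apart on these data.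

Compound 3, `COc1cc2nc(N3CCN(c4ccc(OC(C)C)nn4)CC3)nc(N)c2cc1OC`, differs from compound 2 by 6-isopropoxypyridazin-3-yl in place of 6-propoxypyrimidin-4-yl on an amine nitrogen in a ring. Among the compounds with values here, this change sits at the same place as the only measured step: the swap of one six-membered aromatic ring with two heteroatoms for another on the ring nitrogen, which between compound 1 and compound 2 moved the number by no more than the scatter, a 1.1-fold lower number from compound 1 to compound 2 (0.05 log units; within the scatter). Within the data shown here, no other step bears on the question. The expectation for compound 3 is therefore a step of about a 1.1-fold higher number from compound 2 to compound 3 (0.05 log units; within the scatter) in this assay, that is, no change beyond the scatter. Compound 3 is expected to give 0.4 nM, with a range from 0.15 nM to 1.1 nM.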

Compound 3, inhibition constant: 0.29 nM
Beside the measured number, compound 3's estimate is 1.4-fold (0.14 log units) above it; the range from low to high includes it.
By their numbers in this assay, from the lowest: compounds 3, 2 and 1 (each within the scatter of the next).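

Compound 3 shows that this position tolerates more than a swap of one bare ring for another. Replacing hydrogen with isopropoxy on an aromatic carbon of the ring on the amine nitrogen gives a 1.4-fold lower number from compound 1 to compound 3 (0.14 log units; within the scatter) in this assay, so the added group brings no change that can be told from the scatter, and the low readings hold with this larger group in place. Rearranging the same atoms, with 6-isopropoxypyridazin-3-yl in place of 6-propoxypyrimidin-4-yl, gives a 1.2-fold lower number from compound 2 to compound 3 (0.09 log units; within the scatter), so neither the ring type nor the shape of the three-carbon chain, taken as one combined change, separates these two compounds, and nothing here explains why these changes leave the number within the scatter.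

Going by these compounds, that combined change alters the ring and the chain at once, so the part played by each alone stays unknown. On these data alone, it also remains open whether an amine or a carboxylic acid in place of the isopropoxy, or a longer chain such as butoxy, would move the number beyond the scatter, since all three compounds shown sit within it.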